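The source may hold more compounds than are shown below. What is called first, only, known or untested is meant among the compounds shown, and "the series" means these compounds.

Measured so far:
compound 1 `CNC(=O)CN1CC[C@H](n2c(Nc3ccccc3)nc3cnc(Nc4ccc(N5CCN(C)CC5)cc4)nc32)C1`: 170 nM
compound 2 `CNC(=O)CN1CC[C@H](n2c(Nc3ccc(F)cc3)nc3cnc(Nc4ccc(N5CCN(C)CC5)cc4)nc32)C1`: 1520 nM

Among the measured compounds shown here, in a functional assay on HCC827 cells (Homo sapiens) for antiproliferative activity, read by MTT assay, with a stated time of 72 h (a higher number here means a weaker inhibitor, a lower number a stronger inhibitor), compound 1 stands lowest of the two numbers; the only measured step, an 8.9-fold higher number from compound 1 to compound 2 (0.95 log units; beyond the scatter), comes from fluoro in place of hydrogen on an aromatic carbon and leaves the pyrrolidine substituent untouched. Compound 3 `CN1CCN(c2ccc(Nc3ncc4nc(Nc5ccccc5)n([C@@H]5CCN(S(=O)(=O)C6CC6)C5)c4n3)cc2)CC1` differs from compound 1 by 1-(cyclopropylsulfonyl)pyrrolidin-3-yl in place of 1-((methylcarbamoyl)methyl)pyrrolidin-3-yl on an aromatic nitrogen. For the measured compounds named here, no measured step bears on this change, so neither a size nor a direction can be drawn from the data, and no step beyond the scatter is assumed. Compound 3 is therefore expected to give about 250 nM in this assay, between 60 nM and 1000 nM. The expected step is a 1.5-fold higher number from compound 1 to compound 3 (0.17 log units; within the scatter), estimated to lie within the usual scatter.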

Compound 3, half-maximal inhibitory concentration: 0.88 nM
Estimate against measurement, compound 3: 280-fold (2.45 log units) above, and the stated range ends above it.
By their numbers in this assay, from the lowest: compound 3; then compound 1; then compound 2.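

The group on the aromatic nitrogen of the five-membered ring matters far more than the fluoro change did: in this assay, there is a 190-fold lower number from compound 1 to compound 3 (2.29 log units; beyond the scatter), against an 8.9-fold higher number from compound 1 to compound 2 (0.95 log units; beyond the scatter). The entering group has no hydrogen-bond donor and adds a three-membered ring and a sulfur, but this single pair cannot separate these differences. Nothing measured here explains the step.

Still open, as far as these compounds go, is whether the sulfonyl or the cyclopropyl part carries the gain, which a methylsulfonyl or cyclopropylcarbonyl group in its place could test. From the compounds shown here alone, the effect of fluoro on compound 3 also remains open.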